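The compounds below may be only part of what the source reports. "The series", "measured", "known", "first", "only" and "open" are said of these compounds alone.

Measured so far in a functional assay (aorta) with Rattus norvegicus as the target; a higher number here means a weaker inhibitor, a lower number a stronger inhibitor:
compound 1 `CCO/C(O)=C1\C(COCCn2cc(N)n(C)c2=O)=NC(C)=C(C(=O)OC)C1c1ccccc1Cl`, 25.1 nM;
compound 2 `CCO/C(O)=C1\C(COCCn2cc(N)nc2O)=NC(C)=C(C(=O)OC)C1c1ccccc1Cl`, 31.6 nM.

Compound 2 sits alongside compound 1: the step of a 1.3-fold higher number from compound 1 to compound 2 (0.10 log units; within the scatter) is within the scatter, so the two numbers are not distinguished. Compound 3 `CCO/C(O)=C1\C(COCCN2CC(=O)N(C)C2=O)=NC(C)=C(C(=O)OC)C1c1ccccc1Cl` is not yet measured in this assay; it differs from compound 2 by 3-methyl-2,4-dioxoimidazolidin-1-yl in place of 4-amino-2-hydroxy-1H-imidazol-1-yl on a saturated chain carbon, two bonds along the chain from an oxygen on a saturated carbon. Going by the values given here, only one measured step concerns this position, a 1.3-fold higher number from compound 1 to compound 2 (0.10 log units; within the scatter), and it stayed within the scatter. For compound 3 the expected step is a 1.1-fold higher number from compound 2 to compound 3 (0.04 log units; within the scatter), not beyond the scatter. Compound 3 is estimated at 35 nM, with a range of 14 nM to 90 nM.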

Compound 3, half-maximal inhibitory concentration: 25.1 nM
Compound 3: the middle estimate sits 1.4-fold (0.14 log units) above what was measured; the measured number falls inside the stated range.
By their numbers in this assay, from the lowest: compounds 1, 3 and 2 (each within the scatter of the next).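

In this assay, a non-aromatic ring without hydrogen-bond donors, 3-methyl-2,4-dioxoimidazolidin-1-yl, is not distinguished from either aromatic ring group: the readings are a 1.3-fold lower number from compound 2 to compound 3 (0.10 log units; within the scatter) and no change at the digits printed from compound 1 to compound 3 (within the scatter). At this position, aromaticity of the ring therefore makes no difference beyond the scatter among the three compounds shown. No supporting evidence bears on this result. Still open, on these data alone, is whether a carboxylic acid, a simple amine or a longer chain in place of the ring would give a step beyond the scatter.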